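The compounds below may be only part of what the source reports. "The series", "measured", "known", "first", "only" and "open" are said of these compounds alone.

Compound 3 `CC(C)/C=N/NC(=O)c1ccc(O[C@@H]2O[C@H](CO)[C@@H](O)[C@H](O)[C@H]2O)cc1` carries an isopropyl on a carbon with a double bond to nitrogen. In a functional assay on MDA-MB-231 cells (Homo sapiens) for inhibition, read by MTT assay, with a stated time of 24 h, tested at 100 uM (on this read-out lower numbers stand for less inhibition and higher numbers for more inhibition at the one concentration tested (going by the name of the read-out)), compound 3 gives 1.7%, the lowest of the three numbers shown, though only one of the others stands beyond the scatter from it. For the measured compounds named here, compound 1 `CCCCC/C=N/NC(=O)c1ccc(O[C@@H]2O[C@H](CO)[C@@H](O)[C@H](O)[C@H]2O)cc1` is its nearest neighbour and in this assay compound 1 gives 11%; the single measured step between them, isopropyl in place of pentyl, gave a number 9.3 percentage points lower from compound 1 to compound 3 (within the scatter). Compound 2 `CCCCCc1nnc(-c2ccc(O[C@@H]3O[C@H](COC(C)=O)[C@@H](OC(C)=O)[C@H](OC(C)=O)[C@H]3OC(C)=O)cc2)o1` lies furthest away, and in this assay compound 2 gives 21.5%. Compound 4 `COc1ccc(/C=N/NC(=O)c2ccc(O[C@@H]3O[C@H](CO)[C@@H](O)[C@H](O)[C@H]3O)cc2)cc1` is the next step from compound 3: 4-methoxyphenyl in place of isopropyl on a carbon with a double bond to nitrogen. Only the step from compound 1 to compound 3 touches the same carbon, and it was within the scatter; no measured step exchanges an alkyl group for an aromatic ring, so nothing shown speaks for a large move. Compound 4 is therefore expected to show a number 8.3 percentage points higher from compound 3 to compound 4 (within the scatter) in this assay, not clearly beyond the scatter. Compound 4 is estimated at 10%, within a range from 0% to 28%.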

Compound 4, a percentage reported as inhibition, at one concentration (the size of the read-out at that concentration, not a potency): 11.3%
The estimate for compound 4 lay 1.3 percentage points below the measured number; low and high end bracket the measured number.
By their numbers in this assay, from the lowest: compounds 3, 1 and 4 (each within the scatter of the next); then compound 2.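

Placing an aromatic ring on the carbon with a double bond to nitrogen, as 4-methoxyphenyl with its one six-membered aromatic ring and its hydrogen-bond acceptor, gave a number 9.6 percentage points higher from compound 3 to compound 4 (within the scatter) and a number 0.3 percentage points higher from compound 1 to compound 4 (within the scatter) in this assay for this exchange. Isopropyl, pentyl and 4-methoxyphenyl therefore all stand within the scatter of one another at this position, so the change from an alkyl group to this larger aromatic group did not separate compound 4 from the two alkyl compounds. No measured information here offers an explanation for this result.

The compounds shown leave open whether an amine or a carboxylic acid on the aromatic ring, or a chain longer than pentyl on the same carbon, would move the number beyond the scatter. They also leave open what part of the higher number of compound 2 belongs to any single one of its differences from the other compounds.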